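The compounds below may be only part of what the source reports. "The series", "measured", "known", "first", "only" and "open" are said of these compounds alone.

Working notes on the hydrazone series. Three compounds have been run in an ADME assay on Vero cells (Chlorocebus sabaeus) for cytotoxicity, read by MTT assay, with a stated time of 72 h; on this read-out lower numbers stand for stronger inhibition and higher numbers for weaker inhibition. Compound 1 `COc1ccc2c(N/N=C/c3cccc(O)c3)ccnc2c1` gives 1.09 ug/mL. Compound 2 `COc1ccc2c(N/N=C/c3ccc(N(C)C)cc3)ccnc2c1` gives 0.26 ug/mL. Compound 3 `COc1ccc2c(N/N=C/c3ccc4ccccc4c3)ccnc2c1` gives 0.454 ug/mL, which is the second highest of the three numbers: its nearest neighbour is compound 2, whose number lies within the scatter of it, while compound 1 sits furthest away, with a number beyond the scatter of compound 3 in the direction of weaker inhibition. No pair among these three differs in only one place, so none of the gaps is read as a single structural step.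

Compound 4 `COc1ccc2cc(/C=N/Nc3ccnc4cc(OC)ccc34)ccc2c1` is the next member and is still to be measured in this assay. Relative to compound 3 it carries methoxy in place of hydrogen on an aromatic carbon. No comparable single-point change has been measured in this series, so there is no basis for expecting a shift beyond the scatter in either direction; compound 4 is expected to land close to compound 3, and the expected step is a 1.1-fold higher number from compound 3 to compound 4 (0.04 log units; within the scatter). The estimate for compound 4 in this assay is 0.5 ug/mL, with a range from 0.2 ug/mL to 1.2 ug/mL.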

Compound 4, half-maximal inhibitory concentration: 0.211 ug/mL
The estimate for compound 4 lay 2.4-fold (0.37 log units) above the measured number, within the range that was stated.
By their numbers in this assay, from the lowest: compounds 4, 2 and 3 (each within the scatter of the next, the first and the last beyond it); then compound 1.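

Within the data shown here, this is the first single-place step: in this assay, methoxy in place of hydrogen on an aromatic carbon gives a 2.2-fold lower number from compound 3 to compound 4 (0.33 log units; beyond the scatter). The step is modest but beyond the scatter, so this carbon, on a six-membered aromatic ring of carbon only within a fused system of two rings, meta to a fused ring and para to a fused ring, is a place where a change can move the number, here towards stronger inhibition. Nothing at hand bears on why the number moves with this change.

As far as these compounds go, whether this step is particular to methoxy stays open, as a hydroxy group, a fluorine atom or a longer chain such as ethoxy at the same carbon could give a different result. Also open, from the compounds shown here alone, is whether methoxy on another carbon of the fused system would give a similar step.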